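The compounds below may be only part of what the source reports. "The series", "measured", "known", "first", "only" and "open" are said of these compounds alone.

In a functional assay on M4E cells (Homo sapiens) for cytotoxicity, read by resazurin assay, with a stated time of 72 h (on this read-out higher numbers stand for weaker inhibition and lower numbers for stronger inhibition), compound 3 `COc1cc(/C=C/C(=O)OCCCCO[N+](=O)[O-])ccc1OCCCCO[N+](=O)[O-]` reaches only the limit of > 50000 nM, which is not a number but the edge of the assay. Compound 1 `O=C(/C=C/c1ccc(OCCCCO[N+](=O)[O-])c(O)c1)OCCCCO[N+](=O)[O-]` likewise stops at the limit of > 50000 nM. The change between them is hydrogen in place of methyl on an oxygen on an aromatic ring, and the step that the two limits leave unreadable from compound 3 to compound 1 cannot be read, because of the limit of > 50000 nM in this assay, at which 3 of the 3 values shown sit. Compound 2 `COc1cc(/C=C/C(=O)OCCCO[N+](=O)[O-])ccc1OCCCO[N+](=O)[O-]` also sits at the limit of > 50000 nM. The difference between the core of compound 2 and the core of compound 3 is not broken down here. Compound 4 `O=C(/C=C/c1ccc(OCCCO[N+](=O)[O-])c(O)c1)OCCCO[N+](=O)[O-]` differs from compound 2 by hydrogen in place of methyl on an oxygen on an aromatic ring, the same change as from compound 3 to compound 1. Among the compounds with values here, since every value so far is a limit, the expected step that the limit leaves unreadable from compound 2 to compound 4 rests on compound 2 staying where it is. The expected result for compound 4 is 100000 nM, between 40000 nM and 300000 nM.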

Compound 4, half-maximal inhibitory concentration: 14100 nM
Beside the measured number, compound 4's estimate is 7.1-fold (0.85 log units) above it; measured number below the stated range.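

In this assay, putting hydroxy in place of methoxy on the core of compound 2 gives an at least 3.5-fold lower number from compound 2 to compound 4 (0.54 log units; beyond the scatter), so on this core the change goes with stronger inhibition. Going by these compounds, compound 2 stands at a limit of the assay rather than a true number, so the full size of this step stays unknown. Whether the gain carries over to a second core is not shown, because the same change from compound 3 to compound 1 cannot be read: the limit of > 50000 nM in this assay, at which 3 of the 4 values shown sit.

Also open, on these data alone, is what an amine or a carboxylic acid in place of the nitrate ester groups would do in this assay.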